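Secondary amine series: ring size and hydroxyl-to-amine swap

The source may hold more compounds than are shown below. What is called first, only, known or untested is meant among the compounds shown, and "the series" means these compounds.

The pair measured so far in a functional assay on RKO cells (Homo sapiens) for antiproliferative activity, read by MTT assay, with a stated time of 5 days (on this read-out higher numbers stand for weaker inhibition and lower numbers for stronger inhibition), spans a wide gap. Compound 1 `COc1cc[nH]c1/C=C1\C(=O)Nc2ccc([N+](=O)[O-])c(N3CC[C@H](O)C3)c21` gives 37 nM in this assay. Compound 2 `COc1cc[nH]c1/C=C1\C(=O)Nc2ccc([N+](=O)[O-])c(N[C@H]3CC[C@H](O)CC3)c21` gives 8040 nM in this assay, the higher of the two numbers, and it stands apart from compound 1 by a 220-fold higher number from compound 1 to compound 2 (2.34 log units; beyond the scatter), where the change is (4-hydroxycyclohexyl)amino in place of 3-hydroxypyrrolidin-1-yl on an aromatic carbon.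

Compound 3 `COc1cc[nH]c1/C=C1\C(=O)Nc2ccc([N+](=O)[O-])c(N[C@H]3CC[C@H](N)C3)c21` keeps the secondary amine of compound 2 and changes the ring on it: 3-aminocyclopentyl in place of 4-hydroxycyclohexyl on a nitrogen on an aromatic ring. For the measured compounds named here, no measured step covers this change; the only step known, from compound 1 to compound 2, alters the linker itself and not the ring carried on an intact amine, so it bears on the present step only by showing how sharply this assay can respond to changes at that position. With nothing directly comparable, a step of no clear direction beyond the scatter is expected, with wide uncertainty.

Compound 3 is therefore estimated at 4000 nM in this assay, within a range from 600 nM to 20000 nM, which corresponds to an expected step of a 2.0-fold lower number from compound 2 to compound 3 (0.30 log units; within the scatter).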

Compound 3, half-maximal inhibitory concentration: < 15 nM
Compound 3: no number, only a limit (the forecaster's own chance of this, stated with the estimate: 5%); middle value at least 260-fold (2.42 log units) away from the limit.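

Keeping the amine nitrogen and swapping only the group on it, 3-aminocyclopentyl in place of 4-hydroxycyclohexyl, gives an at least 530-fold lower number from compound 2 to compound 3 (2.72 log units; beyond the scatter) in this assay, so the weak read-out of the (4-hydroxycyclohexyl)amino group is not shared by both compounds with a secondary amine; the group carried on that nitrogen can decide the result by itself. The comparison with the pyrrolidine series also turns around, with an at least 2.4-fold lower number from compound 1 to compound 3 (0.39 log units; beyond the scatter), so a secondary amine at this position is not tied to a poor number and (3-aminocyclopentyl)amino goes beyond 3-hydroxypyrrolidin-1-yl here. Both steps rest on a limit and not on a number, so their true size is unsettled: the limit of < 15 nM in this assay, at which 1 of the 3 values shown sits.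

The ring size and the terminal group change together in the swap from 4-hydroxycyclohexyl to 3-aminocyclopentyl, and the compounds shown do not tell which of the two carries the step. From the compounds shown here alone, a 4-aminocyclohexyl or a 3-hydroxycyclopentyl group on the same nitrogen would separate the two changes, and the stereochemistry of the amine on the cyclopentyl ring also remains open.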